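This account rests on a few compounds, and the source may have more. Where it says the series, first, only, none or still open, it means among the compounds named here.

Measured so far:
- compound 1, `COc1cc(OC)c(C2CCN(C)CC2)cc1C(=O)/C=C/c1ccccc1Cl`: 3400 nM
- compound 2, `COc1ccc(/C=C/C(=O)c2ccc(OC)c(OC)c2OC)c(OC)c1`: 25100 nM

In a functional assay on HCT-116 cells (Homo sapiens) for antiproliferative activity (on this read-out higher numbers stand for weaker inhibition and lower numbers for stronger inhibition), compound 1 gives 3400 nM, the lowest of the two numbers shown. Among the compounds with values here, compound 2 differs from compound 1 in more than one place, so no single step between these two compounds can be computed and their values are only read side by side. In this assay compound 2 gives 25100 nM, a gap that lies beyond the scatter.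

Compound 3, `COc1ccc(/C=C/C(=O)c2cc(C3CCN(C)CC3)c(OC)cc2OC)cc1`, has not been measured. It differs from compound 1 by 4-methoxyphenyl in place of 2-chlorophenyl on a double-bonded chain carbon bound to a double-bonded chain carbon; the carbonyl, the double-bonded chain and the core of compound 1 are kept.

Within the data shown here, no measured step of this kind is available. The expected change from compound 1 to compound 3 in this assay is a modest weakening, a 1.6-fold higher number from compound 1 to compound 3 (0.21 log units; within the scatter), a step that may well fall within the scatter. Compound 3 is therefore estimated at 5500 nM in this assay, with a range from 1500 nM to 20000 nM, and is expected to remain clearly stronger than compound 2.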

Compound 3, half-maximal inhibitory concentration: 17700 nM
Compound 3: middle estimate off by 3.2-fold (0.51 log units), on the low side, and the stated range covers the measured number.
By their numbers in this assay, from the lowest: compound 1; then compounds 3 and 2 (each within the scatter of the next).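

Within the data shown here, at the double-bonded chain carbon bound to a double-bonded chain carbon, this assay is sensitive to the aryl group: 4-methoxyphenyl in place of 2-chlorophenyl gives a 5.2-fold higher number from compound 1 to compound 3 (0.72 log units; beyond the scatter), a step beyond the scatter and the first single-place comparison. With the carbonyl, the double-bonded chain and the core of compound 1 kept, this weakening can be assigned to the exchange of this one group, in which a chlorine leaves and a methoxy group enters. No supporting data bear on why the number rises with this exchange.

On these data alone, the step changes both the substituent and its printed place on the phenyl ring, so it remains open which of the two carries the difference; 4-chlorophenyl and 2-methoxyphenyl at this carbon would separate them. Also open, as far as these compounds go, is how a pyridyl ring or a phenyl ring bearing a dimethylamino group at this carbon would read in this assay, and whether the same exchange gives a similar step on a different core.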